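The compounds below may be only part of what the source reports. "The series", "measured", "known", "first", "only" and "open" are said of these compounds alone.

Compound 3 `CN(C)CC[C@H](CSc1ccccc1)Nc1ccc(S(=O)(=O)NC(=O)c2ccc(N3CCC(=Cc4ccccc4Cl)CC3)cc2)cc1[N+](=O)[O-]` gives 0.7 nM in an assay on isolated protein for displacement of a labelled ligand from Apoptosis regulator Bcl-2 (Homo sapiens), read by fluorescence polarization (a higher number here means a weaker inhibitor, a lower number a stronger inhibitor), the lowest of the two numbers measured here. Its nearest neighbour is compound 1 `CCCCCC1(OC)CCN(c2ccc(C(=O)NS(=O)(=O)c3ccc(N[C@H](CCN(C)C)CSc4ccccc4)c([N+](=O)[O-])c3)cc2)CC1`, which in this assay gives 20 nM. Compound 2 `COC1(Cc2ccccc2-c2ccccc2)CCN(c2ccc(C(=O)NS(=O)(=O)c3ccc(N[C@H](CCN(C)C)CSc4ccccc4)c([N+](=O)[O-])c3)cc2)CC1` gives < 1 nM in this assay, a limit rather than a number, as noted in the limit of < 1 nM in this assay, at which 1 of the 3 values shown sits. For the measured compounds named here, the one step measured in full, an at least 20-fold lower number from compound 1 to compound 2 (1.30 log units; beyond the scatter), is large, and it exchanges the group attached to the saturated ring of the shared core.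

Compound 4 `COc1ccccc1C=C1CCN(c2ccc(C(=O)NS(=O)(=O)c3ccc(N[C@H](CCN(C)C)CSc4ccccc4)c([N+](=O)[O-])c3)cc2)CC1` differs from compound 3 in one place: methoxy in place of chloro on an aromatic carbon. Going by the values given here, no measured step changes a substituent on the aromatic ring that hangs from the saturated ring, so the large step from compound 1 to compound 2 is only a loose guide. Exchanging a chloro for a methoxy is a modest change compared with that step, so the expected step in this assay, a 1.4-fold higher number from compound 3 to compound 4 (0.15 log units; within the scatter), is small and within the usual scatter. Compound 4 is therefore estimated at 1 nM, with a likely range from 0.3 nM to 3.5 nM.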

Compound 4, inhibition constant: 2 nM
For compound 4 the middle estimate is 2.0-fold (0.30 log units) below the measured one; low and high end bracket the measured number.
By their numbers in this assay, from the lowest: compound 3; then compound 4; then compound 1.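

For the compounds shown here, on the aromatic ring hanging from the saturated ring, exchanging chloro for methoxy gives a 2.9-fold higher number from compound 3 to compound 4 (0.46 log units; beyond the scatter) in this assay and this is the first measured change of a substituent at this place. The step is modest but beyond the scatter, so a swap on this ring does register, although it is much smaller than the change of group on the saturated ring, an at least 20-fold lower number from compound 1 to compound 2 (1.30 log units; beyond the scatter) in the same assay. Compound 2 cannot fix the top of this range, since its value is a limit and not a number: the limit of < 1 nM in this assay, at which 1 of the 4 values shown sits.

On these data alone, what a fluoro, a methyl or a hydroxyl at this place would give remains open, as does whether chloro or methoxy elsewhere on this ring would give a step of similar size. With a single step at this place, no trend across groups can be read.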